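The compounds below may be only part of what the source reports. "The series", "measured", "known", "first", "only" and "open" are said of these compounds alone.

Working notes on the series. Within the data shown here, the three measured members share one core with a dithiocarbamate-linked amine varied at the thiocarbonyl carbon. In a functional assay on HeLa cells (Homo sapiens) for antiproliferative activity, read by CCK-8 assay, with a stated time of 72 h, tested at 8 uM (a lower number here means a weaker effect, a higher number a stronger effect of the compound at the concentration tested), compound 1 `Nc1ccccc1NC(=O)c1ccc(CSC(=S)N2CCN(c3cccnc3)CC2)cc1` gives 72.5% and compound 2 `CN(C(=S)SCc1ccc(C(=O)Nc2ccccc2N)cc1)c1cccnc1` gives 70.5%; these two numbers lie within the scatter of each other. Compound 3 `Nc1ccccc1NC(=O)c1ccc(CSC(=S)N2CCCc3ccccc32)cc1` gives 35.7% in this assay, the lowest of the three numbers, with compound 2 nearest and compound 1 furthest, both beyond the scatter. Among the measured compounds shown here, the one step that is known in one place is a number 34.8 percentage points lower from compound 2 to compound 3 (beyond the scatter).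

Compound 4 `CC1CCCCN1C(=S)SCc1ccc(C(=O)Nc2ccccc2N)cc1` is not yet measured in this assay. It differs from compound 3 by 2-methylpiperidin-1-yl in place of 1,2,3,4-tetrahydroquinolin-1-yl on a thiocarbonyl carbon. For the measured compounds named here, no measured step exchanges one amine without a pyridine for another such amine, so the known step from compound 2 to compound 3 bears on this change only loosely: it shows that the size of the read-out can move a long way with the amine on the thiocarbonyl carbon, but both compound 3 and compound 4 carry a saturated ring there and neither carries the pyridin-3-yl found in compound 1 and compound 2. The expectation is therefore a step of a number 4.3 percentage points higher from compound 3 to compound 4 (within the scatter) that stays near the scatter, with compound 4 estimated at 40% in this assay, within a range of 20% to 65%.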

Compound 4, a percentage reported as inhibition, at one concentration (the size of the read-out at that concentration, not a potency): 76.3%
Estimate against measurement, compound 4: 36.3 percentage points below; the measured number lies above the stated range.
By their numbers in this assay, from the lowest: compound 3; then compounds 2, 1 and 4 (each within the scatter of the next).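

At the amine on a thiocarbonyl carbon, 2-methylpiperidin-1-yl in place of 1,2,3,4-tetrahydroquinolin-1-yl gives in this assay a number 40.6 percentage points higher from compound 3 to compound 4 (beyond the scatter) and so shows that the read-out can move a long way between two amines that carry no pyridine. With a number 5.8 percentage points higher from compound 2 to compound 4 (within the scatter) in this assay as the comparison, the pyridin-3-yl of compound 1 and compound 2 is not required for a read-out of this size, and among the four compounds only compound 3, with its 1,2,3,4-tetrahydroquinolin-1-yl, stands apart from the others. Nothing on hand accounts for the position of that group in the series.

The compounds shown do not separate the loss of the six-membered aromatic ring of carbon only from the smaller count of heavy atoms in the entering group, nor do they show what the methyl of 2-methylpiperidin-1-yl contributes. Unsubstituted piperidin-1-yl, morpholin-4-yl and the open-chain diethylamino group on the same thiocarbonyl carbon remain open comparisons, as does whether this picture holds in cells other than those of this assay.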